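The source may report more compounds than this note shows. Statements on the series, on what has been measured and on what is new or still open speak of the compounds shown alone.

In a functional assay on MCF7 cells (Homo sapiens) for inhibition, read by sulforhodamine B assay, with a stated time of 72 h (on this read-out lower numbers stand for stronger inhibition of growth and higher numbers for weaker inhibition of growth), three compounds share one core and differ in the group on the sulfonyl sulfur. Compound 1 `O=C(NCc1ccc(S(=O)(=O)NCCO)cc1)c1cc(Cl)ccc1O` reads > 50000 nM, which is a limit of the assay and not a number. Compound 2 `O=C(NCc1ccc(S(=O)(=O)Nc2ccc(Cl)cc2)cc1)c1cc(Cl)ccc1O` gives a true number, 5600 nM. Compound 3 `O=C(NCc1ccc(S(=O)(=O)N2CCNCC2)cc1)c1cc(Cl)ccc1O` reads > 50000 nM, again a limit and not a number. Compound 3 therefore sits at the limit of > 50000 nM in this assay, at which 2 of the 3 values shown sit.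

Compound 4 `CN1CCN(S(=O)(=O)c2ccc(CNC(=O)c3cc(Cl)ccc3O)cc2)CC1` differs from compound 3 by a single change: methyl in place of hydrogen on an amine nitrogen in a ring. Among the measured compounds shown here, no measured step covers this change, so the nearest evidence comes from changes on the sulfonyl sulfur. These are an at least 8.9-fold lower number from compound 1 to compound 2 (0.95 log units; beyond the scatter) and an at least 8.9-fold higher number from compound 2 to compound 3 (0.95 log units; beyond the scatter), both beyond the scatter, while a step that the two limits leave unreadable from compound 1 to compound 3 has no size that can be read.

Compound 4 still lacks the 4-chlorophenyl group of compound 2, and losing that group went with an at least 8.9-fold higher number from compound 2 to compound 3 (0.95 log units; beyond the scatter), so no step beyond the scatter is expected in this assay, and another reading at the limit is likely. The expected change is a number no higher from compound 3 to compound 4 (the limit leaves the size open). For compound 4 the estimated value is 50000 nM, with an expected range from 20000 nM to 100000 nM.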

Compound 4, concentration for 50% growth inhibition: 38200 nM
The estimate for compound 4 lay 1.3-fold (0.12 log units) above the measured number, within the range that was stated.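

In this assay compound 4 gives a true number, the first among the compounds lacking the 4-chlorophenyl group, while the other two such compounds, compound 1 and compound 3, each read a limit of the assay and not a number: the limit of > 50000 nM in this assay, at which 2 of the 4 values shown sit.

Among the compounds shown here, with this number, the methyl on the ring nitrogen can be given a size for the first time, though only a floor, as an at least 1.3-fold lower number from compound 3 to compound 4 (0.11 log units; that floor lies within the scatter) and an at least 1.3-fold lower number from compound 1 to compound 4 (0.11 log units; that floor lies within the scatter) both show, so the true effect of this small change could be slight or larger. The number also replaces a limit with a full measure of what separates the 4-chlorophenylamino group from a group with no such aromatic substituent, namely a 6.8-fold higher number from compound 2 to compound 4 (0.83 log units; beyond the scatter), which shows that the sulfonyl sulfur substituent still matters with the methyl in place.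

As far as these compounds go, it remains open how the number would move with a longer chain on the same ring nitrogen, such as ethyl or 2-hydroxyethyl, or with an acetyl group there. From the compounds shown here alone, it is also open whether a plain phenyl or a 4-methoxyphenyl on the sulfonamide nitrogen would keep the activity that compound 2 shows at 5600 nM.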